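From fluoro to chloro on a small core

This account rests on a few compounds, and the source may have more. Where it says the series, first, only, none or still open, it means among the compounds named here.

In a functional assay on B16-F10 cells (Mus musculus) for cytotoxicity (on this read-out higher numbers stand for weaker inhibition and lower numbers for stronger inhibition), compound 1 `O=c1cc(O)c2cc(F)ccc2o1` gives 70700 nM. Going by the values given here, compound 2 `O=c1oc2ccccc2c2nc3c(ccc4cc[nH]c43)c(-c3ccc(Cl)cc3Cl)c12`, a much larger structure, gives 70700 nM, so the two stand level and compound 1 sits neither above nor below the only other measured compound.

Compound 3 `O=c1cc(O)c2cc(Cl)ccc2o1` has not yet been measured. It keeps the core of compound 1 but carries chloro in place of fluoro on an aromatic carbon. Among the compounds with values here, compounds 1 and 2 differ in more than one place, so no measured step shows what this swap does. With only one atom exchanged, a small step is expected, probably none beyond the scatter, with a slight lean towards stronger inhibition. The estimated step is a 1.3-fold lower number from compound 1 to compound 3 (0.11 log units; within the scatter). For compound 3 the estimate is 55000 nM, with an expected range from 22000 nM to 120000 nM.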

Compound 3, half-maximal inhibitory concentration: 70700 nM
Compound 3: the middle estimate sits 1.3-fold (0.11 log units) below what was measured, within the range that was stated.
By their numbers in this assay, from the lowest: compounds 1, 2 and 3 (each within the scatter of the next).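

Going by these compounds alone, exchanging fluoro for chloro on the aromatic carbon gives no change at the digits printed from compound 1 to compound 3 (within the scatter) in this assay and is the first single change on this core that can be read. At this place, meta to a fused ring and para to a fused ring, the read-out therefore does not separate these two groups, although a single pair cannot show how the position behaves more widely. The data at hand offer no explanation for this outcome.

From the compounds shown here alone, what stays open is whether a group of a different kind at this place, such as an amine, a carboxylic acid or a longer chain, would shift the number beyond the scatter. The shown compounds also leave unanswered how changes elsewhere on the shared core, for example at its hydroxyl group, would affect the number.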